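The compounds below may be only part of what the source reports. "The series", "measured", "known", "first", "only" and "open" are said of these compounds alone.

Values in a physicochemical assay for lipophilicity, at pH 7.4 (on this read-out lower numbers stand for lower lipophilicity and higher numbers for higher lipophilicity), for the three measured compounds are:
- compound 1 (`COCc1nc2nc(C)cc(Nc3ccc(C(F)(F)F)cc3)n2n1`) gives 2.5
- compound 2 (`Cc1cc(Nc2ccc(S(F)(F)(F)(F)F)cc2)n2nc(C(F)(F)F)nc2n1`) gives 3.7
- compound 3 (`CSc1nc2nc(C)cc(Nc3ccc(C(F)(F)F)cc3)n2n1`) gives 3.2

Compound 2 stands highest of the three, and its gaps down to compound 3 and compound 1 both lie beyond the usual scatter. The unmeasured compound 4 (`Cc1cc(Nc2ccc(S(F)(F)(F)(F)F)cc2)n2nc(C(C)(F)F)nc2n1`) differs from compound 2 by a single exchange (methyl in place of fluoro on a saturated chain carbon bound to an aromatic carbon and two fluorine atoms): methyl in place of fluoro on a saturated chain carbon bound to an aromatic carbon and two fluorine atoms. The same difference also reads as trifluoromethyl to 1,1-difluoroethyl.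

Among the compounds with values here, only one measured step changes a single place (a number 0.70 log units higher from compound 1 to compound 3 (beyond the scatter)), and it is a different exchange, methylsulfanyl in place of methoxymethyl on an aromatic carbon. That step was modest but beyond the scatter. It involves neither fluoro nor methyl, so it offers a sense of scale in this assay and no direction. Within the data shown here, no measured pair tests the exchange itself. Starting from compound 2 at 3.7 and using that step as a yardstick, a smaller downward move is expected, near the edge of the scatter. The expected move is a number 0.30 log units lower from compound 2 to compound 4 (within the scatter) in this estimate. For compound 4 the estimated value is 3.4 with a range from 3 to 3.8 as the expected span.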

Compound 4, distribution coefficient: 3.6
Compound 4: the middle estimate sits 0.20 log units below what was measured; the range from low to high includes it.
By their numbers in this assay, from the lowest: compound 1; then compound 3; then compounds 4 and 2 (each within the scatter of the next).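

Within the data shown here, on this saturated chain carbon, bound to an aromatic carbon and two fluorine atoms, compounds 2 and 4 give the first direct reading of methyl in place of fluoro in this assay, and the outcome is a number 0.10 log units lower from compound 2 to compound 4 (within the scatter). Among these compounds, the only earlier single-place step, a number 0.70 log units higher from compound 1 to compound 3 (beyond the scatter), involved other groups and could say nothing about this exchange, whereas here trifluoromethyl and 1,1-difluoroethyl cannot be told apart on this read-out, at least in this one pair. No measurement presented here bears on why the two compounds cannot be separated.

Still open, from the compounds shown here alone, is what happens at this place when a group other than these two is present, such as an amine, a carboxylic acid or a longer chain, any of which would show whether the read-out can move here at all. Also open, going by these compounds, is whether methyl in place of fluoro would give a similarly small step with the rest of the molecule changed, since a single pair cannot establish a general pattern for this exchange.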